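Pyridyl ketone exchanged for a dimethoxyphenyl ketone

This account rests on a few compounds, and the source may have more. Where it says the series, first, only, none or still open, it means among the compounds named here.

Two measured compounds share a core. Compound 1 `COc1ccc(C(=O)/C=C/c2cn(-c3ccccc3)nc2-c2ccsc2)c(OC)c1` and compound 2 `O=C(/C=C/c1cn(-c2ccccc2)nc1-c1cccnc1)c1ccccn1` were both tested in a functional assay on HCT-116 cells (Homo sapiens) for inhibition, read by sulforhodamine B assay, with a stated time of 72 h; a higher number here means a weaker inhibitor, a lower number a stronger inhibitor. In this assay compound 1 gives 2200 nM, and in this assay compound 2 gives 2100 nM. The two numbers lie within the usual scatter of each other, so compound 2 stands level with compound 1 rather than apart from it; neither can be called the stronger of the pair.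

Compound 3 `COc1ccc(C(=O)/C=C/c2cn(-c3ccccc3)nc2-c2cccnc2)cc1OC` has not yet been measured. It differs from compound 2 in one place: 3,4-dimethoxyphenyl in place of pyridin-2-yl on a carbonyl carbon. Among the compounds with values here, no step between two measured compounds isolates this exchange, but compound 1 already carries a dimethoxyphenyl ketone and gives 2200 nM, a number level with that of compound 2. Compound 3 is therefore expected to stay close to compound 2, with a step in this assay of a 1.2-fold lower number from compound 2 to compound 3 (0.07 log units; within the scatter), which is within the scatter rather than a real change. The estimate for compound 3 in this assay is 1800 nM, with a range from 900 nM to 3600 nM.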

Compound 3, half-maximal inhibitory concentration: 4300 nM
Beside the measured number, compound 3's estimate is 2.4-fold (0.38 log units) below it; the measured number lies above the stated range.
By their numbers in this assay, from the lowest: compounds 2, 1 and 3 (each within the scatter of the next, the first and the last beyond it).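

Within the data shown here, on a carbonyl carbon whose other neighbour is the double-bonded chain carbon, 3,4-dimethoxyphenyl in place of pyridin-2-yl gives in this assay a 2.0-fold higher number from compound 2 to compound 3 (0.31 log units; beyond the scatter) as the first step at this position that can be read between two measured compounds. The step is modest, but it shows that this place in the molecule responds to the exchange, and that pyridin-2-yl gives the lower number of the two groups compared here. The exchange alters several things at once, with a ring nitrogen leaving and two methoxy groups entering, and nothing measured here bears on which of these lies behind the step.

The compounds shown leave open whether a plain phenyl, a phenyl carrying a single methoxy group or a phenyl carrying an amine on the same carbonyl carbon would stand with compound 2 or with compound 3, and whether a carboxylic acid on that ring would be tolerated at all. Among these compounds, they also leave open whether the same exchange would give a step of this size on the core of compound 1, where no such pair is available.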